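Three near-zero readings and a dichlorophenyl analogue

The compounds below may be only part of what the source reports. "The series", "measured", "known", "first", "only" and "open" are said of these compounds alone.

Of the compounds shown here, three sharing one core have been tested in a functional assay on CWR22R cells (Homo sapiens) for inhibition, with a stated time of 120 h, tested at 10 uM; a higher number here means more inhibition at the concentration tested (going by the name of the read-out), a lower number less inhibition. Compound 1 `Cc1n[nH]c2ccc(-c3nc4cnc(N5CCN(C)CC5)cn4c3Nc3cccc(F)c3)cc12` gives 5.41%. Compound 2 `COc1ccc(Nc2c(-c3ccc4[nH]nc(C)c4c3)nc3cnc(N4CCN(C)CC4)cn23)cc1` gives 0%, and compound 3 `Cc1n[nH]c2ccc(-c3nc4cnc(N5CCN(C)CC5)cn4c3Nc3ccc(F)cc3Br)cc12` gives 4.41%. Of the three numbers, that of compound 1 stands at the top, but only by steps that the data themselves call noise: a number 5.4 percentage points lower from compound 1 to compound 2 (within the scatter), and a number 1 percentage points lower from compound 1 to compound 3 (within the scatter). All three readings are therefore indistinguishable and sit close to no inhibition.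

Compound 4 `Cc1n[nH]c2ccc(-c3nc4cnc(N5CCN(C)CC5)cn4c3Nc3cc(Cl)ccc3Cl)cc12` is not yet measured. It differs from compound 1 in one place: 2,5-dichlorophenyl in place of 3-fluorophenyl on a nitrogen on an aromatic ring. The two steps that bear on this change, both swapping the group on the same nitrogen of the core, stayed within the scatter, as did the step between compound 2 and compound 3, a number 4.4 percentage points higher from compound 2 to compound 3 (within the scatter). No step beyond the scatter is therefore expected in this assay . For compound 4 the expected step is a number 0.4 percentage points lower from compound 1 to compound 4 (within the scatter), and its estimated reading is 5%, within a range of 0% to 15%.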

Compound 4, a percentage reported as inhibition, at one concentration (the size of the read-out at that concentration, not a potency): 3.8%
The estimate for compound 4 lay 1.2 percentage points above the measured number; the measured number falls inside the stated range.
By their numbers in this assay, from the lowest: compounds 2, 4, 3 and 1 (each within the scatter of the next).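

With the 2,5-dichlorophenyl group on the nitrogen, this assay shows a number 1.6 percentage points lower from compound 1 to compound 4 (within the scatter), a number 0.6 percentage points lower from compound 3 to compound 4 (within the scatter) and a number 3.8 percentage points higher from compound 2 to compound 4 (within the scatter). Chlorine is new at this position, and it joins 3-fluorophenyl, 2-bromo-4-fluorophenyl and 4-methoxyphenyl in a set of four groups whose readings all lie within the scatter of one another. Nothing available explains why these readings stay so close together.

From the compounds shown here alone, all four compounds carry a substituted phenyl ring on this nitrogen, so it remains open whether a different kind of group there, such as a carboxylic acid or an amine on a longer chain, would change the reading. Going by these compounds, it also remains open whether a change elsewhere on the shared core would do so.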